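A few compounds are considered here, and "the series" means these few. Any claim that something is new, unique, unknown or untested is made for them only; others in the source may bear on it.

Measured so far:
compound 1 `O=C1/C(=C\c2ccc(F)cc2)c2ccccc2N1c1c(Cl)cccc1Cl`, "not determined" (no result reported) in a functional assay on MOLT-4 cells (Homo sapiens) for cytotoxicity, read by MTT assay, with a stated time of 72 h; a higher number here means that more compound is needed for the effect, a lower number that less compound is needed;
compound 2 `O=C1/C(=C\c2cccc(Oc3ccccc3)c2)c2ccccc2N1c1c(Cl)cccc1Cl`, 6 ug/mL in this assay;
compound 3 `COc1ccc(/C=C2\C(=O)N(c3c(Cl)cccc3Cl)c3ccccc32)cc1`, "not determined" (no result reported) in this assay.

For the measured compounds named here, compound 3 thus stands without a number in this assay, and compound 1 is the one further entry without a number, so the only measured value in the set belongs to compound 2. Compound 4 `O=C1/C(=C\c2cccc(Br)c2)c2ccccc2N1c1c(Cl)cccc1Cl` differs from compound 3 by 3-bromophenyl in place of 4-methoxyphenyl on a double-bonded chain carbon bound to a double-bonded ring carbon. Going by the values given here, no step between two measured compounds is available, so the size of the move from compound 3 to compound 4 cannot be set against a measured case, and no direction beyond the usual scatter is expected. Compound 4 is estimated to give about 6 ug/mL in this assay, with an expected range from 2 ug/mL to 20 ug/mL.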

Compound 4, concentration for half-maximal effect: 7 ug/mL
Beside the measured number, compound 4's estimate is 1.2-fold (0.07 log units) below it, within the range that was stated.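

Bromo in place of phenoxy on an aromatic carbon gives a 1.2-fold higher number from compound 2 to compound 4 (0.07 log units; within the scatter) in this assay, the only step between measured compounds in this set. At this aromatic carbon, therefore, phenoxy with its additional aromatic ring and bromo give numbers that cannot be told apart. Nothing available here explains this result. Still open, as far as these compounds go, is whether an amine or a carboxylic acid on this aromatic carbon would give a number in the same range, and whether a longer chain there would do so too.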